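The source may report more compounds than this note shows. Statements on the series, on what has been measured and on what is new or still open speak of the compounds shown alone.

In a functional assay on KB cells (Homo sapiens) for antiproliferative activity, read by sulforhodamine B assay, with a stated time of 3 days (a lower number here means that less compound is needed, a higher number that more compound is needed for the effect), compound 1 `CCC1=C(O)c2c(oc(-c3ccc(C)cc3)cc2=O)C(CC)(CC)C1=O` gives 39.2 uM, compound 2 `CCC1=C(O)c2c(oc(-c3ccc(F)cc3)cc2=O)C(CC)(CC)C1=O` gives 33 uM and compound 3 `CCC1=C(O)c2c(oc(-c3cccc(C)c3)cc2=O)C(CC)(CC)C1=O` gives 49.7 uM. Compound 3 therefore stands level with the other two, within the usual scatter. Compound 4 `CCC1=C(O)c2c(oc(-c3ccccc3F)cc2=O)C(CC)(CC)C1=O` carries one change: 2-fluorophenyl in place of 3-methylphenyl on an aromatic carbon, with 2-fluorophenyl in place of 3-methylphenyl on an aromatic carbon next to the ring oxygen. The closest evidence is a 1.5-fold higher number from compound 2 to compound 3 (0.18 log units; within the scatter), together with a 1.2-fold lower number from compound 1 to compound 2 (0.07 log units; within the scatter), fluoro in place of methyl, and a 1.3-fold higher number from compound 1 to compound 3 (0.10 log units; within the scatter), 3-methylphenyl in place of 4-methylphenyl. Among the measured compounds shown here, all three steps stay within the scatter, but no measured compound carries the 2-fluorophenyl group. No step beyond the scatter is therefore expected in this assay. The estimated change is a 1.2-fold lower number from compound 3 to compound 4 (0.09 log units; within the scatter). For compound 4 the expected value is 40 uM, with an estimated range of 22 uM to 70 uM.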

Compound 4, concentration for half-maximal effect: > 56.2 uM
Compound 4: only a limit was reported; the forecaster's own chance of this, stated with the estimate: 15%; middle value at least 1.4-fold (0.14 log units) away from the limit.
By their numbers in this assay, from the lowest: compounds 2, 1 and 3 (each within the scatter of the next). At a limit, above all of these: compound 4.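

In this assay compound 4 is the first compound with this kind of group at this position to return only a limit rather than a number: the limit of > 56.2 uM in this assay, at which 1 of the 4 values shown sits.

The steps can be read only as floors: an at least 1.1-fold higher number from compound 3 to compound 4 (0.05 log units; that floor lies within the scatter), an at least 1.7-fold higher number from compound 2 to compound 4 (0.23 log units; that floor lies within the scatter) and an at least 1.4-fold higher number from compound 1 to compound 4 (0.15 log units; that floor lies within the scatter). Each floor lies within the scatter, so 2-fluorophenyl cannot yet be separated from the other three groups, although its true value may lie well beyond them.

As far as these compounds go, how far compound 4 really lies past its limit stays open. So does whether an amine or a carboxylic acid on this phenyl ring would shift the number at all.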